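Acetyl in place of dimethylamino: expected loss of effect

The source may hold more compounds than are shown below. What is called first, only, known or untested is meant among the compounds shown, and "the series" means these compounds.

Measured so far:
compound 1, `COc1cc(C)cc(-c2c(-c3ccnc(-c4ccc(N(C)C)cc4)c3)cnn2CC#N)c1`: -27%
compound 2, `COc1cc(C)cc(-c2nn(CC#N)cc2-c2ccc(-c3cccc(C(C)=O)c3)nc2)c1`: 16%

In a functional assay on SF-295 cells (Homo sapiens) for cytotoxicity, read by sulforhodamine B assay, with a stated time of 48 h, tested at 1 uM (a lower number here means a stronger effect, a higher number a weaker effect of the compound at the concentration tested), compound 1 gives -27%, the lowest of the two numbers. Among the measured compounds shown here, compound 2 gives 16%, a gap above compound 1 that is beyond the scatter; the two differ in more than one place, so no single step is read from them.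

Compound 3, `COc1cc(C)cc(-c2c(-c3ccnc(-c4ccc(C(C)=O)cc4)c3)cnn2CC#N)c1`, is not yet measured. It differs from compound 1 in one place: acetyl in place of dimethylamino on an aromatic carbon.

For the measured compounds named here, the only measured compound carrying an acetyl is compound 2, whose 16% stands well above compound 1; this is the sole lead. The step of a number 32 percentage points higher from compound 1 to compound 3 (beyond the scatter) is therefore expected to run upward, toward a weaker effect, and probably beyond the scatter, though with little support. Compound 3 is estimated at 5%, within a range from -25% to 35%.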

Compound 3, a percentage reported as activity, at one concentration (the size of the read-out at that concentration, not a potency): 39%
The estimate for compound 3 lay 34 percentage points below the measured number; measured number outside the range, above it.
By their numbers in this assay, from the lowest: compound 1; then compound 2; then compound 3.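

In this assay, among the compounds shown here, the swap of dimethylamino for acetyl gives the first single-place comparison: a number 66 percentage points higher from compound 1 to compound 3 (beyond the scatter). The position on the aromatic carbon para to a large group is therefore sensitive, with the read-out depending strongly on which of these two groups sits there while the rest of compound 1 stays unchanged. The two groups have the same counts of heavy atoms, hydrogen-bond donors and hydrogen-bond acceptors, so those counts do not separate them, and nothing available here explains the step.

From the compounds shown here alone, it remains open where an unsubstituted amine, a diethylamino group or a carboxylic acid would fall at this position relative to compound 1 and compound 3. Also open, going by these compounds, is whether the same change would give a step of similar size on the core of compound 2.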